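Terminal halogen swap on the alkynyl chain of compound 2

The source may report more compounds than this note shows. Statements on the series, on what has been measured and on what is new or still open speak of the compounds shown alone.

compound 1, `CCCCCCCCCCc1cc2cn([C@H]3C[C@H](O)[C@@H](CO)O3)c(=O)nc2o1`: in a functional assay on HEL cells (Homo sapiens) for cytotoxicity (a lower number here means that less compound is tolerated, a higher number that more compound is tolerated), a limit of the assay only, > 50000 nM
compound 2, `O=c1[nH]c(=O)n([C@H]2C[C@H](O)[C@@H](CO)O2)cc1C#CCCCCCCCCCF`: in this assay 116000 nM

For the measured compounds named here, compound 2 holds the only numeric reading in this set. For compound 1 the reading is a limit of the assay and not a number (the limit of > 50000 nM in this assay, at which 1 of the 2 values shown sits). Going by the values given here, with one number and one limit there is no measured step in this assay from which to calibrate a structural change.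

Compound 3, `O=c1[nH]c(=O)n([C@H]2C[C@H](O)[C@@H](CO)O2)cc1C#CCCCCCCCCCCl`, is not yet measured. It differs from compound 2 by chloro in place of fluoro on a saturated chain carbon, nine bonds along the chain from a triple-bonded carbon. The rest of the molecule, the shared core with its sugar and the long alkynyl chain, is unchanged.

For a swap of one halogen for another at the far end of a saturated chain, the expectation is a step that does not go beyond the usual scatter in this assay, in no particular direction. The step expected is a 1.2-fold lower number from compound 2 to compound 3 (0.06 log units; within the scatter). Compound 3 is therefore estimated at 100000 nM, within a range of 40000 nM to 250000 nM, with a real chance that the assay returns only a limit.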

Compound 3, half-maximal cytotoxic concentration: 74000 nM
For compound 3 the middle estimate is 1.4-fold (0.13 log units) above the measured one, and the stated range covers the measured number.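

In this assay the series now has its first measured step: a 1.6-fold lower number from compound 2 to compound 3 (0.20 log units; within the scatter) for chloro in place of fluoro on a saturated chain carbon, nine bonds along the chain from a triple-bonded carbon. For this one pair, then, the two halogens at the far end of the alkynyl chain cannot be told apart in this read-out, and the halogen swap gives the series a first small reference step, although a single pair says nothing about other changes at this position. Compound 1 remains a limit of the assay and not a number, and no step from it can be read: the limit of > 50000 nM in this assay, at which 1 of the 3 values shown sits.

Going by these compounds, what a group other than a halogen would do at this chain end stays open: a terminal hydroxyl, an amine or a carboxylic acid in the same place could stay within the scatter or go beyond it, and this pair gives no hint either way. On these data alone, a bromo or iodo end is equally unplaced, as is a longer chain carrying chloro, so the reach of this result along the chain remains unknown.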